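Swapping the Aryl Group at the Chain Carbon

A few compounds are considered here, and "the series" means these few. Any claim that something is new, unique, unknown or untested is made for them only; others in the source may bear on it.

Measured so far:
compound 1 `O=C(O)CC(c1ccc(OCC2COc3ccc(Cl)cc3O2)cc1)c1cnco1` gives 1030 nM in a functional assay on HEK293 cells for agonist activity at Free fatty acid receptor 1 (Homo sapiens), read by fluorescence and calcium flux, with a stated time of 10 min; a higher number here means that more compound is needed for the effect, a lower number that less compound is needed
compound 2 `O=C(O)CC(c1ccc(F)cc1)c1ccc(OCC2COc3ccc(Cl)cc3O2)cc1` gives 4310 nM in this assay

Compound 2 holds the higher of the two numbers; the step of a 4.2-fold higher number from compound 1 to compound 2 (0.62 log units; beyond the scatter) separates it from compound 1. Compound 3 `O=C(O)CC(c1ccncc1)c1ccc(OCC2COc3ccc(Cl)cc3O2)cc1` has not been measured. The change is pyridin-4-yl in place of 4-fluorophenyl on a saturated chain carbon bound to an aromatic carbon and a saturated chain carbon. Within the data shown here, the only step that bears on it is a 4.2-fold higher number from compound 1 to compound 2 (0.62 log units; beyond the scatter), where an aromatic ring with hetero atoms was swapped for the fluorophenyl group and the number rose. Returning to a heteroaromatic ring, compound 3 is therefore expected to show a modest drop, a 2.2-fold lower number from compound 2 to compound 3 (0.33 log units; beyond the scatter). Compound 3 is estimated at 2000 nM, within 700 nM to 5500 nM.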

Compound 3, half-maximal effective concentration: 1170 nM
Compound 3: the middle estimate sits 1.7-fold (0.23 log units) above what was measured; the measured number falls inside the stated range.
By their numbers in this assay, from the lowest: compounds 1 and 3 (each within the scatter of the next); then compound 2.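

Pyridin-4-yl in place of 4-fluorophenyl on the saturated chain carbon gives a clear drop (a 3.7-fold lower number from compound 2 to compound 3 (0.57 log units; beyond the scatter)), so the return to a lower number is not limited to 1,3-oxazol-5-yl but also occurs with a six-membered aromatic ring with a hetero atom. The two heteroaromatic groups cannot be told apart (a 1.1-fold higher number from compound 1 to compound 3 (0.06 log units; within the scatter)), leaving 4-fluorophenyl alone at the higher number among these compounds. Nothing available explains this difference. From the compounds shown here alone, it remains open whether a plain phenyl, a pyridin-3-yl or a dimethylamino group at this carbon would match 4-fluorophenyl or the two heteroaromatic groups.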